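The source may report more compounds than this note shows. Statements on the series, on what has been measured and on what is new or still open speak of the compounds shown alone.

Measured compounds:

Compound 1 `O=C(CC(CC(=O)NC1Cc2ccccc2C1)c1ccccc1)NCCN1CCCC1`: in a functional assay on MCF7 cells (Homo sapiens) for inhibition (on this read-out lower numbers stand for stronger inhibition and higher numbers for weaker inhibition), compound 1 reaches only the limit > 100000 nM, which is a limit of the assay and not a number.
Compound 2 `CCN(CC)CCNC(=O)CC(CC(=O)NC1Cc2ccccc2C1)c1ccccc1`: in this assay compound 2 likewise reaches only the limit > 100000 nM.
Among the measured compounds shown here, compound 3 `CCN(C(=O)CC(CC(=O)NCCN1CCCC1)c1ccc(Cl)cc1)C1Cc2ccccc2C1`: in this assay compound 3 gives 20400 nM, the only number in the set.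

The change from compound 1 to compound 2 is diethylamino in place of pyrrolidin-1-yl on a saturated chain carbon, two bonds along the chain from an amide-type nitrogen. Its size is a step that the two limits leave unreadable from compound 1 to compound 2, because of the limit of > 100000 nM in this assay, at which 2 of the 3 values shown sit. How the core of compound 3 differs from the core of compound 1 is not broken down here.

Compound 4 `CCN(CC)CCNC(=O)CC(CC(=O)N(CC)C1Cc2ccccc2C1)c1ccc(Cl)cc1` is not yet measured in this assay. It arises from compound 3 by the same kind of change, (diethylamino in place of pyrrolidin-1-yl on a saturated chain carbon, two bonds along the chain from an amide-type nitrogen). For the measured compounds named here, since the only earlier instance of this change left no readable step, the expectation for compound 4 rests on compound 3 alone, at 20400 nM. The step from compound 3 to compound 4 is expected to be a 1.0-fold lower number from compound 3 to compound 4 (0.01 log units; within the scatter), within the usual scatter. Compound 4 is therefore estimated at 20000 nM, between 7000 nM and 60000 nM.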

Compound 4, half-maximal inhibitory concentration: 23000 nM
Compound 4: middle estimate off by 1.2-fold (0.06 log units), on the low side, and the stated range covers the measured number.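

In this assay, diethylamino in place of pyrrolidin-1-yl on the core of compound 3 gives a 1.1-fold higher number from compound 3 to compound 4 (0.05 log units; within the scatter) and so the two amines cannot be told apart on this core. This single readable step does not show that the change behaves alike on other cores. The same change on the core of compound 1 cannot be read, because both values there are limits of the assay and not numbers: the limit of > 100000 nM in this assay, at which 2 of the 4 values shown sit.

The compounds shown leave open whether piperidin-1-yl, morpholin-4-yl or a longer chain to the amine would read differently from pyrrolidin-1-yl and diethylamino on the core of compound 3. Also open, on these data alone, is how that core would read with fluoro or methoxy in place of the chloro group.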